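This account rests on a few compounds, and the source may have more. Where it says the series, first, only, none or still open, it means among the compounds named here.

Measured in a functional assay on HT-29 cells (Homo sapiens) for antiproliferative activity, read by MTT assay, with a stated time of 96 h; a higher number here means a weaker inhibitor, a lower number a stronger inhibitor:
- Compound 1 `O=C1NNC(=O)C2(CSC3=C2C(=O)c2ncccc2C3=O)N1`: 1580 nM; 1600 nM; 1600 nM (3 entries)
- Compound 2 `O=C1C2=C(C(=O)c3ncccc31)C1(CS2)NC(=O)N(c2ccccc2)C1=O`: 2 nM

For the measured compounds named here, compound 2 stands at 2 nM, the only number available for it in this assay. One further entry for compound 2 gives no single number, so its position rests on a single reading. The entries for compound 1 agree closely (the several entries of compound 1 in this assay, 1580 nM; 1600 nM; 1600 nM (3 entries)), and at 1580 nM; 1600 nM; 1600 nM (3 entries) compound 1 lies far above compound 2.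

Compound 3 `COc1ccc(N2C(=O)NC3(CSC4=C3C(=O)c3ncccc3C4=O)C2=O)cc1` differs from compound 2 in one place: methoxy in place of hydrogen on an aromatic carbon. This is methoxy in place of hydrogen on an aromatic carbon, turning phenyl to 4-methoxyphenyl. Going by the values given here, no measured pair tests this change, so the expectation starts from compound 2 at 2 nM and stays modest. A small step towards weaker inhibition is expected, possibly no larger than the usual scatter, and the wide range reflects the thin evidence. The expected change is a 2.5-fold higher number from compound 2 to compound 3 (0.40 log units; beyond the scatter). For compound 3 the estimated value is 5 nM, with an expected range from 1 nM to 40 nM.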

Compound 3, half-maximal inhibitory concentration: 2 nM
Compound 3: the middle estimate sits 2.5-fold (0.40 log units) above what was measured, and the stated range covers the measured number.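

In this assay, for the compounds shown here, methoxy in place of hydrogen on an aromatic carbon, turning phenyl to 4-methoxyphenyl, gives no change at the digits printed from compound 2 to compound 3 (within the scatter) and is the first measured test of this change. The place para to a large group on the phenyl ring therefore carries a methoxy group without a step beyond the scatter, with compound 2 at 2 nM and compound 3 at 2 nM in the same assay, so the low number for compound 2 no longer stands alone within this pair. Nothing in the available evidence bears on why this replacement leaves the reading as it is.

As far as these compounds go, the pair covers one replacement at one place, so it remains open whether an amine, a carboxylic acid, a fluorine atom or a longer chain such as butoxy at the same place would read alike. It also remains open whether a methoxy group elsewhere on the phenyl ring would give the same result, since the compounds shown place it only para to a large group.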